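A few compounds are considered here, and "the series" means these few. Any claim that something is new, unique, unknown or untested is made for them only; others in the source may bear on it.

Compound 1 `CC(O)c1cccc(C(=O)N[C@@H](C)Cn2ccc(-c3ccc(C#N)c(Cl)c3)n2)c1`, compound 2 `COc1ccc(C(=O)N[C@@H](C)Cn2ccc(-c3ccc(C#N)c(Cl)c3)n2)cc1` and compound 3 `COC(=O)/C=C/C(=O)N[C@@H](C)Cn1ccc(-c2ccc(C#N)c(Cl)c2)n1` share one core and differ only in the group on the carbonyl carbon. In a functional assay on LNCaP cells (Homo sapiens) for antiproliferative activity, read by CCK-8 assay, with a stated time of 6 days (on this read-out lower numbers stand for stronger inhibition and higher numbers for weaker inhibition), compound 1 gives 2280 nM, compound 2 gives 3410 nM and compound 3 gives 2460 nM. Compound 3 stands second highest of the three, with compound 1 nearest and compound 2 furthest. The steps of a 1.5-fold higher number from compound 1 to compound 2 (0.17 log units; within the scatter), a 1.1-fold higher number from compound 1 to compound 3 (0.03 log units; within the scatter) and a 1.4-fold lower number from compound 2 to compound 3 (0.14 log units; within the scatter) all lie within the scatter. Compound 4 `C[C@@H](Cn1ccc(-c2ccc(C#N)c(Cl)c2)n1)Nc1cccnc1` carries pyridin-3-yl in place of (2-(methoxycarbonyl)ethenyl)carbonyl on an amine nitrogen. Going by the values given here, no measured step removes the carbonyl, so no direct precedent exists; with all acyl swaps within the scatter, a step in this assay beyond the scatter is not expected in either direction, though the range must be wide. Compound 4 is estimated at 2500 nM, from 700 nM to 9000 nM, which is expected to mean a 1.0-fold higher number from compound 3 to compound 4 (0.01 log units; within the scatter).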

Compound 4, half-maximal inhibitory concentration: 430 nM
Compound 4: middle estimate off by 5.8-fold (0.76 log units), on the high side; the measured number lies below the stated range.
By their numbers in this assay, from the lowest: compound 4; then compounds 1, 3 and 2 (each within the scatter of the next).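

Replacing the acyl group on the amine nitrogen with pyridin-3-yl gives a 5.7-fold lower number from compound 3 to compound 4 (0.76 log units; beyond the scatter) in this assay, whereas the steps among compounds 1, 2 and 3 all stay within the scatter. Going by these compounds alone, this position can therefore shift the read-out when the change goes beyond swapping the group on the carbonyl carbon, though only this single pair shows it. No measurement here accounts for the step.

This change removes the carbonyl and introduces the ring together, and the compounds shown do not separate the two. A phenyl on the same amine nitrogen would test whether the pyridine nitrogen matters.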